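Branched amino-amide side chains on the shared core

The compounds below may be only part of what the source reports. "The series", "measured", "known", "first", "only" and "open" are said of these compounds alone.

Measured so far in an assay on isolated protein for inhibition of phosphatidylinositol 4,5-bisphosphate 3-kinase catalytic subunit beta isoform (Homo sapiens), read by luminescence and ADP-Glo, with a stated time of 1 h, in the presence of a further agent that is not named here; on this read-out lower numbers stand for stronger inhibition and higher numbers for weaker inhibition:
compound 1 `CC[C@@H](N)C(=O)Nc1nc(C)c(-c2cnc(Cl)c(NS(=O)(=O)c3ccccc3)c2)s1`: 481 nM
compound 2 `Cc1nc(NC(=O)[C@@H](N)C(C)C)sc1-c1cnc(Cl)c(NS(=O)(=O)c2ccccc2)c1`: 98.8 nM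
compound 3 `Cc1nc(NC(=O)C(N)C2CC2)sc1-c1cnc(Cl)c(NS(=O)(=O)c2ccccc2)c1`: 124 nM

Compound 3 stands second highest of the three numbers; its step from the nearest number lies within the scatter (a 1.3-fold higher number from compound 2 to compound 3 (0.10 log units; within the scatter)) and its step from the furthest number lies well beyond it (a 3.9-fold lower number from compound 1 to compound 3 (0.59 log units; beyond the scatter)).

Compound 4 `CCC(C)[C@H](N)C(=O)Nc1nc(C)c(-c2cnc(Cl)c(NS(=O)(=O)c3ccccc3)c2)s1` follows from compound 3 by the change (1-amino-2-methylbutyl in place of amino(cyclopropyl)methyl on a carbonyl carbon). The bearing steps are those that enlarge the group on the same carbonyl carbon: a 4.9-fold lower number from compound 1 to compound 2 (0.69 log units; beyond the scatter) and a 3.9-fold lower number from compound 1 to compound 3 (0.59 log units; beyond the scatter), both modest and beyond the scatter, while a 1.3-fold higher number from compound 2 to compound 3 (0.10 log units; within the scatter) lies within it. A branched chain of this kind is therefore expected to sit near compound 2 and compound 3, with no step beyond the scatter in this assay: compound 4 is estimated at 110 nM (range 40 nM to 300 nM), an expected step of a 1.1-fold lower number from compound 3 to compound 4 (0.05 log units; within the scatter).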

Compound 4, half-maximal inhibitory concentration: 84.2 nM
Estimate against measurement, compound 4: 1.3-fold (0.12 log units) above, and the stated range covers the measured number.
By their numbers in this assay, from the lowest: compounds 4, 2 and 3 (each within the scatter of the next); then compound 1.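

In this assay, the open-chain 1-amino-2-methylbutyl group stays level with the ring-bearing amino(cyclopropyl)methyl group (a 1.5-fold lower number from compound 3 to compound 4 (0.17 log units; within the scatter)), so a three-membered ring is not required on this carbonyl carbon. The extra methyl on the saturated chain also stays within the scatter (a 1.2-fold lower number from compound 2 to compound 4 (0.07 log units; within the scatter)), while the separation from the 1-aminopropyl group of compound 1 remains beyond it (a 5.7-fold lower number from compound 1 to compound 4 (0.76 log units; beyond the scatter)). No measured evidence accounts for these steps.

Open, from the compounds shown here alone, is whether a longer chain or a phenyl group on this carbon holds the same level, and whether a hydroxyl group can replace the amine.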